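Swapping a Hydroxy for Fluoro on a Retinoid Scaffold

The compounds below may be only part of what the source reports. "The series", "measured", "known", "first", "only" and "open" are said of these compounds alone.

Compound 1 `CC1(C)CCC(C)(C)c2c(F)cc(C(=O)c3ccc4cc(C(=O)O)ccc4c3)cc21` gives 100% in an assay on isolated protein with retinoic acid receptor gamma (Homo sapiens) as the target; on this read-out lower numbers stand for smaller maximal responses and higher numbers for larger maximal responses. Compound 2 `CC1(C)CCC(C)(C)c2cc(C(O)c3ccc4cc(C(=O)O)ccc4c3)c(O)cc21` gives 47% in this assay, the lower of the two numbers, and its gap to compound 1 lies beyond the usual scatter. Compound 3 `CC1(C)CCC(C)(C)c2cc(C(O)c3ccc4cc(C(=O)O)ccc4c3)c(F)cc21` carries one change from compound 2: fluoro in place of hydroxy on an aromatic carbon. For the measured compounds named here, compound 1, the only measured compound bearing fluoro, also differs from compound 2 in other places, so no single-point comparison exists. A modest rise is expected, a number 13 percentage points higher from compound 2 to compound 3 (beyond the scatter), which may not exceed the scatter. Compound 3 is estimated to reach 60%, between 35% and 90%.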

Compound 3, largest response reached (reported as maximum), in percent of the reference or control that the assay uses: 70%
For compound 3 the middle estimate is 10 percentage points below the measured one, within the range that was stated.
By their numbers in this assay, from the lowest: compound 2; then compound 3; then compound 1.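

In this assay, placing fluoro in place of hydroxy on this aromatic carbon gives a number 23 percentage points higher from compound 2 to compound 3 (beyond the scatter) and so shows that this one change alone moves the maximal response, which the earlier pair, differing in more than one place, could not show. The change takes away a hydrogen-bond donor and a hydrogen-bond acceptor, yet nothing available links that loss to the rise. Open, going by these compounds, is how chloro or methoxy on the same carbon would compare with fluoro and hydroxy, and whether the step would be the same size on a different core.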